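This account rests on a few compounds, and the source may have more. Where it says the series, first, only, none or still open, it means among the compounds named here.

Measured in a functional assay on SGC-7901 cells (Homo sapiens) for cytotoxicity, read by MTT assay, with a stated time of 48 h; on this read-out lower numbers stand for stronger inhibition and higher numbers for weaker inhibition:

compound 1, `COc1ccc(-c2nnc(SCCn3c([N+](=O)[O-])cnc3C)o2)cc1`: 10200 nM
compound 2, `CCOc1ccc(-c2nnc(SCCn3c([N+](=O)[O-])cnc3C)o2)cc1`: 14100 nM
compound 3, `COc1ccc(-c2nnc(SCCn3c([N+](=O)[O-])cnc3C)o2)c(O)c1`: 11700 nM

All three numbers lie close together. Compound 1 is separated from its neighbours only by a 1.4-fold higher number from compound 1 to compound 2 (0.14 log units; within the scatter) and by a 1.1-fold higher number from compound 1 to compound 3 (0.06 log units; within the scatter), so on these numbers none of the three stands apart from the others.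

Compound 4, `Cc1ncc([N+](=O)[O-])n1CCSc1nnc(-c2ccco2)o1`, has not been measured yet. It differs from compound 1 in one place: furan-2-yl in place of 4-methoxyphenyl on an aromatic carbon. The two measured steps both alter the 4-methoxyphenyl group rather than replace it, and both stayed within the scatter. Among the measured compounds shown here, no measured step exchanges the whole six-membered ring for a five-membered one, so there is no direct guide for this change. With the group on this position having shown little effect so far, the expectation for compound 4 is a number close to that of compound 1, with a step of a 1.2-fold higher number from compound 1 to compound 4 (0.07 log units; within the scatter) that is not expected to pass beyond the scatter. Compound 4 is therefore estimated at 12000 nM, within a range from 5000 nM to 30000 nM.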

Compound 4, half-maximal inhibitory concentration: 31700 nM
For compound 4 the middle estimate is 2.6-fold (0.42 log units) below the measured one; measured number outside the range, above it.
By their numbers in this assay, from the lowest: compounds 1, 3 and 2 (each within the scatter of the next); then compound 4.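

Exchanging the whole 4-methoxyphenyl group for furan-2-yl gives a step beyond the scatter in this assay, with a 3.1-fold higher number from compound 1 to compound 4 (0.49 log units; beyond the scatter), whereas the two smaller alterations to that group stayed within it. This position therefore does respond to what it carries, and here the exchange of a six-membered aromatic ring of carbon only for a five-membered aromatic ring with 1 hetero atom goes with weaker inhibition. Nothing available explains why the number moves.

Going by these compounds, it remains open whether the step follows the smaller ring, the ring oxygen or the loss of the methoxy group, since this single exchange changes all three at once. On these data alone, a plain phenyl, thiophen-2-yl or pyridin-2-yl group on this carbon could help separate these, and where each would fall is unknown.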